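Two chlorines traded for two methoxy groups on a diamine core

The compounds below may be only part of what the source reports. "The series", "measured", "known", "first", "only" and "open" are said of these compounds alone.

Of the compounds shown here, three sharing one core have been tested in a functional assay on SF-539 cells (Homo sapiens) for inhibition, read by sulforhodamine B assay, with a stated time of 48 h; on this read-out lower numbers stand for higher toxicity in this test and higher numbers for lower toxicity in this test. Compound 1 `Nc1cc(N)c2nc(-c3ccccc3)c(Oc3ccc(Cl)c(Cl)c3)nc2c1` carries a 3,4-dichlorophenyl joined to the core through an oxygen; in this assay compound 1 gives 64600 nM. Compound 2 `CCOC(=O)[C@H](CCC(=O)O)NC(=O)c1ccc(CNc2nc3cc(N)cc(N)c3nc2-c2ccccc2)cc1` bears a much longer side chain ending in a glutamate ester; for compound 2 this assay reports only a limit, < 100000 nM, and not a number. Compound 3 `Nc1cc(N)c2nc(-c3ccccc3)c(NCc3ccc(Cl)c(Cl)c3)nc2c1` has the 3,4-dichlorophenyl joined through a saturated carbon and a nitrogen; in this assay compound 3 gives 83200 nM. Of the two numbers actually read, compound 3 shows the higher one, but its distance to compound 1 is within the scatter, so the two cannot be told apart.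

Compound 4 `COc1ccc(CNc2nc3cc(N)cc(N)c3nc2-c2ccccc2)cc1OC` is not yet measured. It differs from compound 3 by 3,4-dimethoxyphenyl in place of 3,4-dichlorophenyl on a saturated chain carbon bound to a nitrogen on an aromatic ring. Within the data shown here, with no comparable step among the measured compounds, the expectation rests on the weak toxicity shared by compound 1 and compound 3. For compound 4 the step from compound 3 is expected to be a 1.1-fold higher number from compound 3 to compound 4 (0.06 log units; within the scatter), a small movement toward weaker toxicity. Compound 4 is therefore expected to give about 95000 nM in this assay, with a range from 45000 nM to 200000 nM.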

Compound 4, concentration lethal to 50% of the cells: < 100000 nM
Compound 4: no number, only a limit; the forecaster's own chance of this, stated with the estimate: 45%; the middle value does not contradict the limit.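

In this assay compound 4 gives only a limit and not a number, so the step from compound 3 to compound 4 cannot be read: the limit of < 100000 nM in this assay, at which 2 of the 4 values shown sit.

Whether 3,4-dimethoxyphenyl in place of 3,4-dichlorophenyl changes the toxicity in this test at all, and in which direction, remains open with the compounds shown.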